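A Basic Amine Chain Replaces the Aryl Amide Cap

The compounds below may be only part of what the source reports. "The series", "measured", "known", "first", "only" and "open" are said of these compounds alone.

Of the compounds shown here, three sharing one core have been measured in a functional assay on 143B cells (Homo sapiens) for inhibition, read by MTT assay, with a stated time of 72 h; a lower number here means a stronger inhibitor, a higher number a weaker inhibitor. Compound 1 `O=C(CCC(=O)OCCCCCCSc1ccc([N+](=O)[O-])c2nonc12)Nc1ccccc1F` gives 3030 nM. Compound 2 `Cc1ccccc1NC(=O)CCC(=O)OCCCCCCSc1ccc([N+](=O)[O-])c2nonc12` gives 4660 nM, and compound 3 `Cc1ccc(NC(=O)CCC(=O)OCCCCCCSc2ccc([N+](=O)[O-])c3nonc23)cc1` gives 3250 nM. Compound 1 has the lowest of these three numbers, yet its steps to the others are small: a 1.5-fold higher number from compound 1 to compound 2 (0.19 log units; within the scatter) and a 1.1-fold higher number from compound 1 to compound 3 (0.03 log units; within the scatter), while between the other two a 1.4-fold lower number from compound 2 to compound 3 (0.16 log units; within the scatter). All three sit within the scatter of one another, so none can be called stronger than the rest.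

Compound 4 `CN(C)CCNC(=O)CCC(=O)OCCCCCCSc1ccc([N+](=O)[O-])c2nonc12` has not yet been measured. It differs from compound 1 in one place: 2-(dimethylamino)ethyl in place of 2-fluorophenyl on an amide-type nitrogen. Every measured step exchanged one aryl group for another, and each stayed within the scatter. Among the compounds with values here, none exchanged an aryl group for a chain, so no measured step speaks directly to this change. With the shared core untouched and all three known values close together, compound 4 is expected to show a 1.3-fold higher number from compound 1 to compound 4 (0.12 log units; within the scatter), a shift that may not exceed the scatter. For compound 4 the estimate in this assay is 4000 nM, expected to lie between 1500 nM and 12000 nM.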

Compound 4, half-maximal inhibitory concentration: 2190 nM
Compound 4: middle estimate off by 1.8-fold (0.26 log units), on the high side, and the stated range covers the measured number.
By their numbers in this assay, from the lowest: compounds 4, 1, 3 and 2 (each within the scatter of the next, the first and the last beyond it).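

At this position on the amide-type nitrogen, the aromatic ring can be replaced by 2-(dimethylamino)ethyl, a group with no ring, and the number in this assay remains in the same low-micromolar range as before. Against the two closest aryl compounds the change stays small, with a 1.4-fold lower number from compound 1 to compound 4 (0.14 log units; within the scatter) and a 1.5-fold lower number from compound 3 to compound 4 (0.17 log units; within the scatter), so in these pairs the loss of the ring brings no measurable change, while compound 2 is the exception, showing a 2.1-fold lower number from compound 2 to compound 4 (0.33 log units; beyond the scatter), a modest step and the first in this set to pass the scatter. No measurement on these compounds offers a reason for this result.

The compounds shown leave open whether the dimethylamino group itself matters or whether the two-carbon chain alone would do, a question that a plain alkyl chain or a chain carrying a hydroxyl group in place of the amine could address. They also leave open how a longer chain between the amide nitrogen and the amine, or a ring amine such as morpholine or piperidine, would behave in this assay.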